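Replacing the 3-bromophenyl group of compound 3

The source may report more compounds than this note shows. Statements on the series, on what has been measured and on what is new or still open speak of the compounds shown alone.

Compound 1 `O=C(Nc1ccccc1)C1CCN(C/C=C/c2ccccc2)CC1`: 60200 nM
Compound 2 `COc1ccccc1NC(=O)C1CCN(C/C=C/c2ccccc2)CC1`: > 100000 nM (a limit of the assay)
Compound 3 `O=C(Nc1cccc(Br)c1)C1CCN(C/C=C/c2ccccc2)CC1`: 11500 nM

In a functional assay on MCF7 cells (Homo sapiens) for inhibition, read by MTT assay, with a stated time of 72 h (a lower number here means a stronger inhibitor, a higher number a weaker inhibitor), compound 3 has the lowest number of the series, and compound 1 is its nearest measured neighbour. Compound 4 `O=C(Nc1ccccn1)C1CCN(C/C=C/c2ccccc2)CC1` carries pyridin-2-yl in place of 3-bromophenyl on an amide-type nitrogen. This change removes the bromo group, which gave a 5.2-fold lower number from compound 1 to compound 3 (0.72 log units; beyond the scatter). The comparison with the methoxy compound gives an at least 8.6-fold lower number from compound 2 to compound 3 (0.93 log units; beyond the scatter), while an at least 1.6-fold higher number from compound 1 to compound 2 (0.22 log units; that floor lies within the scatter) adds little. Among the compounds with values here, no measured step covers the pyridin-2-yl group itself. A higher number of modest size is therefore expected in this assay, and the expected step is a 3.9-fold higher number from compound 3 to compound 4 (0.59 log units; beyond the scatter). For compound 4 the estimate is 45000 nM, with an expected range of 15000 nM to 100000 nM.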

Compound 4, half-maximal inhibitory concentration: 67200 nM
For compound 4 the middle estimate is 1.5-fold (0.17 log units) below the measured one; low and high end bracket the measured number.
By their numbers in this assay, from the lowest: compound 3; then compounds 1 and 4 (each within the scatter of the next). At a limit, above all of these: compound 2.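

Pyridin-2-yl does not hold the level of the 3-bromophenyl group in this assay, with a 5.8-fold higher number from compound 3 to compound 4 (0.77 log units; beyond the scatter). Against the plain phenyl group, pyridin-2-yl gives a 1.1-fold higher number from compound 1 to compound 4 (0.05 log units; within the scatter), so of these three groups only 3-bromophenyl stands apart. Compound 2 stands at a limit of the assay: the limit of > 100000 nM in this assay, at which 1 of the 4 values shown sits. Pyridin-2-yl in place of 2-methoxyphenyl gives an at least 1.4-fold lower number from compound 2 to compound 4 (0.17 log units; that floor lies within the scatter), which is a floor only.

Going by these compounds, whether the lower number of compound 3 is specific to bromo stays open. A chloro group or an amine on the phenyl ring lies outside the compounds shown.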